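Two chalcone-like pyrazoles and an untested difluoro analogue

The source may hold more compounds than are shown below. What is called first, only, known or untested is meant among the compounds shown, and "the series" means these compounds.

Measured so far:
compound 1, `COc1cc(-c2cc(/C=C/C(=O)c3ccc(N)cc3)[nH]n2)cc(OC)c1OC`: 105%
compound 2, `COc1ccc(C(=O)/C=C/c2cc(-c3cc(OC)c(OC)c(OC)c3)n[nH]2)cc1`: 92%

Both compounds were tested in a functional assay on NCI-H23 cells (Homo sapiens) for cytotoxicity, read by sulforhodamine B assay, with a stated time of 48 h, tested at 0.1 uM; a lower number here means a stronger effect, a higher number a weaker effect of the compound at the concentration tested. Compound 1 gives 105%, and compound 2 gives 92%. Compound 2 has the lower of the two numbers: the change from a number 13 percentage points lower from compound 1 to compound 2 (beyond the scatter). On the numbers shown, compound 2 therefore stands at the lower end, with compound 1 as its only neighbour.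

Compound 3, `COc1cc(-c2cc(/C=C/C(=O)c3ccc(F)c(F)c3)[nH]n2)cc(OC)c1OC`, has not yet been measured. It differs from compound 2 in one place: 3,4-difluorophenyl in place of 4-methoxyphenyl on a carbonyl carbon. Within the data shown here, no measured step bears on this change. Among the measured compounds shown here, the single measured step, a number 13 percentage points lower from compound 1 to compound 2 (beyond the scatter), concerns a different position and a different pair of groups, so it says nothing direct about swapping the 4-methoxyphenyl for the 3,4-difluorophenyl. The two numbers in hand lie close together, so the expectation for compound 3 is a step in this assay of no particular direction and probably not beyond the scatter, a number 3 percentage points higher from compound 2 to compound 3 (within the scatter). Compound 3 is estimated at 95%, with a range from 78% to 110%.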

Compound 3, a percentage reported as activity, at one concentration (the size of the read-out at that concentration, not a potency): 92%
Compound 3: middle estimate off by 3 percentage points, on the high side; measured number inside the range.
By their numbers in this assay, from the lowest: compounds 2 and 3 (each within the scatter of the next); then compound 1.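

In this assay, placing 3,4-difluorophenyl instead of 4-methoxyphenyl on the carbonyl carbon gives no change at the digits printed from compound 2 to compound 3 (within the scatter), so at this position, a group with no hydrogen-bond acceptor and one with a single acceptor cannot be told apart, even though their atoms differ. Placing 3,4-difluorophenyl instead of 4-aminophenyl at the same carbon gives a number 13 percentage points lower from compound 1 to compound 3 (beyond the scatter), which matches in size the earlier step of a number 13 percentage points lower from compound 1 to compound 2 (beyond the scatter) and shows that, among these three compounds, only the 4-aminophenyl compound stands apart from the others. No measurement here explains why these groups compare as they do.

The compounds shown leave open how other groups on the carbonyl carbon would read out, such as 4-hydroxyphenyl, 4-chlorophenyl, or a phenyl ring carrying a carboxylic acid, and whether any of them would move the number further than either the 4-methoxyphenyl or the 3,4-difluorophenyl group does. They also leave open whether the same order would hold at other concentrations, as each number reports the size of the read-out at one concentration and is not a potency.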